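This account rests on a few compounds, and the source may have more. Where it says the series, first, only, none or still open, it means among the compounds named here.

The measured compounds in a physicochemical assay for solubility, read by HPLC, with a stated time of 24 h; on this read-out higher numbers stand for higher solubility and lower numbers for lower solubility:
compound 1, `O=C1O[C@@H](CN2CCCCC2)CN1c1ccc(-n2cc(-c3ccccn3)cn2)c(F)c1`, 219000 nM;
compound 3, `O=C1CSC(=O)N1C[C@H]1CN(c2ccc(-n3cc(-c4ccccn4)cn3)c(F)c2)C(=O)O1`, 26900 nM.
Compound 2, `O=C1O[C@@H](CN2CCC(c3ccc(F)cc3)CC2)CN1c1ccc(-n2cc(-c3ccccn3)cn2)c(F)c1`, sits at a limit of this assay, <= 19400 nM, as recorded in the limit of <= 19400 nM in this assay, at which 1 of the 3 values shown sits.

Among the two plain numbers, compound 3 stands lowest; its nearest neighbour is separated from it by the step of an 8.1-fold lower number from compound 1 to compound 3 (0.91 log units; beyond the scatter). Compound 4, `CN(C)S(=O)(=O)NC[C@H]1CN(c2ccc(-n3cc(-c4ccccn4)cn3)c(F)c2)C(=O)O1`, differs from compound 3 by one change: (dimethylsulfamoyl)amino in place of 2,4-dioxo-1,3-thiazolidin-3-yl on a saturated chain carbon bound to a saturated ring carbon. Within the data shown here, no measured step follows this exact exchange. The two steps recorded, an at least 11-fold lower number from compound 1 to compound 2 (1.05 log units; beyond the scatter) and an 8.1-fold lower number from compound 1 to compound 3 (0.91 log units; beyond the scatter), both start from compound 1 and both run downward; neither starts from compound 3 nor replaces one neutral group with another. They therefore offer only a rough scale for the size a single change at this position can take. Among the measured compounds shown here, with no direct precedent, compound 4 is expected to stay near compound 3, with a step of about a 1.5-fold higher number from compound 3 to compound 4 (0.17 log units; within the scatter), well inside the scatter. The estimated value for compound 4 is 40000 nM, within a range of 12000 nM to 130000 nM.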

Compound 4, solubility: 472000 nM
The estimate for compound 4 lay 12-fold (1.07 log units) below the measured number, outside the stated range (above it).
By their numbers in this assay, from the lowest: compound 3; then compound 1; then compound 4. At a limit, below all of these: compound 2.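

Among these compounds, the only earlier exchange at this place, on a saturated chain carbon bound to a saturated ring carbon, had lowered the number from compound 1, but in this assay (dimethylsulfamoyl)amino gives the opposite direction: a 2.2-fold higher number from compound 1 to compound 4 (0.33 log units; beyond the scatter). Replacing 2,4-dioxo-1,3-thiazolidin-3-yl with this group, with no net charge on either side, gives an 18-fold higher number from compound 3 to compound 4 (1.24 log units; beyond the scatter), so an exchange that leaves net charge unchanged can still move the number a long way at this place. Nothing measured among the compounds shown bears on this result.

The loss of the ring and the gain of a hydrogen-bond donor occur together between compound 3 and compound 4, and the compounds shown do not separate them. Also open, as far as these compounds go, is how a primary amine or a carboxylic acid at this place would compare with (dimethylsulfamoyl)amino.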